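Aryl swap on the ring nitrogen: compound 3 to compound 4

The source may hold more compounds than are shown below. What is called first, only, known or untested is meant among the compounds shown, and "the series" means these compounds.

Among the measured compounds shown here, compound 3 `Cc1cc(N(Cc2ccc(C(=O)NCCC(=O)O)cc2)c2nc(-c3ccc(C(F)(F)F)cc3)cs2)ccc1C(C)C` gives 93 nM in an in vitro assay on BHK cells for binding affinity to Glucagon receptor (Homo sapiens) (on this read-out higher numbers stand for weaker inhibition and lower numbers for stronger inhibition), the highest of the three numbers measured so far. Compound 1 `O=C(O)CCNC(=O)c1ccc(CC(c2ccc(Cl)cc2)c2nc(-c3ccc(C(F)(F)F)cc3)cs2)cc1` gives 38 nM and compound 2 `O=C(O)CCNC(=O)c1ccc(CC(c2ccc(Cl)cc2)c2nc(-c3ccc(OC(F)(F)F)cc3)cs2)cc1` gives 25 nM; both numbers lie beyond the scatter from compound 3, with compound 1 the nearer of the two. Compound 4 `O=C(O)CCNC(=O)c1ccc(CN(c2ccc(OC(F)(F)F)cc2)c2nc(-c3ccc(C(F)(F)F)cc3)cs2)cc1` is not yet measured; the change from compound 3 is 4-(trifluoromethoxy)phenyl in place of 4-isopropyl-3-methylphenyl on a nitrogen on an aromatic ring. For the measured compounds named here, the only measured step in the set is a 1.5-fold lower number from compound 1 to compound 2 (0.18 log units; within the scatter), which does involve a trifluoromethoxy group but on the other aryl ring of the shared core, and between two compounds whose variable aryl sits on a carbon rather than on the nitrogen. Going by the values given here, no measured step bears directly on this swap. What the numbers show is that compounds 1 and 2, which lack the 4-isopropyl-3-methylphenyl group, both give lower numbers than compound 3. The expected step is a 1.9-fold lower number from compound 3 to compound 4 (0.27 log units; within the scatter), moving towards those numbers, with wide uncertainty. Compound 4 is expected at 50 nM, within a range of 15 nM to 170 nM.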

Compound 4, half-maximal inhibitory concentration: 51 nM
Estimate against measurement, compound 4: 1.0-fold (0.01 log units) below; low and high end bracket the measured number.
By their numbers in this assay, from the lowest: compounds 2, 1, 4 and 3 (each within the scatter of the next, the first and the last beyond it).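

In this assay, among the compounds shown here, the step at this position is a 1.8-fold lower number from compound 3 to compound 4 (0.26 log units; within the scatter), the first reading of a change to the aryl group on the nitrogen. Here 4-(trifluoromethoxy)phenyl, which carries oxygen and fluorine and counts one hydrogen-bond acceptor, stands in for the all-carbon 4-isopropyl-3-methylphenyl, and the read-out does not move beyond the scatter. So this position accepts two quite different substituted phenyl groups with no resolved difference, and nothing on hand explains why.

Open is how far this tolerance extends: an amine, a nitrile or a carboxylic acid on this aryl ring would test it beyond the two groups shown. No pair shown differs only at the nitrogen, so the role of that atom relative to the carbon in compound 1 also remains unresolved.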